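Methoxy for chloro: compound 4 expected to stay at the limit

The compounds below may be only part of what the source reports. "The series", "measured", "known", "first", "only" and "open" are said of these compounds alone.

Compound 3 `Cc1cc(CCC(=O)O)ccc1-c1noc(-c2ccc(OC(C)C)c(Cl)c2)n1` is one of three entries in a functional assay on CHO cells with sphingosine 1-phosphate receptor 2 (Homo sapiens) as the target, read by GTPgammaS binding (a lower number here means that less compound is needed, a higher number that more compound is needed for the effect), all at a limit. In this assay compound 3 gives > 10000 nM, a limit. Compound 1 `Cc1ccccc1-c1noc(-c2ccc(C3CCCCC3)cc2)n1` gives > 10000 nM, also a limit. Compound 2 `Cc1cc(CC(=O)O)ccc1-c1noc(-c2ccc(C3CCCCC3)cc2)n1` gives > 10000 nM, again a limit. Among the compounds with values here, the single step between measured neighbours, a step that the two limits leave unreadable from compound 1 to compound 2, is therefore unreadable, and the limit of > 10000 nM in this assay, at which 3 of the 3 values shown sit, says the same of the whole set. Compound 4 `COc1cc(-c2nc(-c3ccc(CCC(=O)O)cc3C)no2)ccc1OC(C)C` differs from compound 3 by methoxy in place of chloro on an aromatic carbon. Within the data shown here, no measured step bears on this change, so no direction can be read from the data. Compound 4 is expected at 15000 nM, with a range of 5000 nM to 50000 nM, most likely reported as a limit once more. The step that the limit leaves unreadable from compound 3 to compound 4 is expected to be none beyond the scatter.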

Compound 4, half-maximal effective concentration: > 10000 nM
Compound 4 gave a limit, no number; the forecaster's own chance of this, stated with the estimate: 85%; the middle value lies beyond the limit too.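

Compound 3 and compound 4 both stand at a limit in this assay, so no new step can be read: the limit of > 10000 nM in this assay, at which 4 of the 4 values shown sit.
The compounds shown leave open which change, if any, would give a number rather than a limit in this assay.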